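The source may report more compounds than this note shows. Statements on the series, on what has been measured and on what is new or still open speak of the compounds shown alone.

Measured compounds in a functional assay on PC-3 cells (Homo sapiens) for antiproliferative activity, read by MTT assay, with a stated time of 48 h; on this read-out lower numbers stand for stronger inhibition and higher numbers for weaker inhibition

Compound 1 `CC1(C)Cc2c(ccc(C(=O)/C=C/c3cn(-c4ccccc4)nc3-c3ccccc3)c2OCc2ccccc2)O1` gives > 100000 nM in this assay, which is a limit of the assay and not a number.
Compound 2 `CC1(C)Cc2c(ccc(C(=O)/C=C/c3cn(-c4ccccc4)nc3-c3ccc([N+](=O)[O-])cc3)c2OCc2ccccc2)O1` gives 62300 nM in this assay.
Compound 3 `CC1(C)Cc2c(ccc(C(=O)/C=C/c3cn(-c4ccccc4)nc3-c3ccc(Cl)cc3)c2OCc2ccccc2)O1` gives 26000 nM in this assay.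

Compound 3 holds the lowest of the two numbers shown; its nearest neighbour is compound 2, with a 2.4-fold lower number from compound 2 to compound 3 (0.38 log units; beyond the scatter). Compound 1 stands at the limit of > 100000 nM in this assay, at which 1 of the 3 values shown sits.

Compound 4 `COc1ccc(-c2nn(-c3ccccc3)cc2/C=C/C(=O)c2ccc3c(c2OCc2ccccc2)CC(C)(C)O3)cc1` differs from compound 3 in one place: methoxy in place of chloro on an aromatic carbon. Within the data shown here, three measured steps touch the same aromatic carbon. Chloro entering for hydrogen gave an at least 3.8-fold lower number from compound 1 to compound 3 (0.58 log units; beyond the scatter), nitro entering for hydrogen gave an at least 1.6-fold lower number from compound 1 to compound 2 (0.20 log units; that floor lies within the scatter), and chloro replacing nitro gave a 2.4-fold lower number from compound 2 to compound 3 (0.38 log units; beyond the scatter). None of these steps involves methoxy, so the change from compound 3 to compound 4 is not directly covered. The two substituted compounds, compound 2 and compound 3, both sit below the limit of compound 1, and chloro is the better of the two. On that footing compound 4 is expected to fall somewhere between the values of compound 3 and compound 2, most likely with a modest rise, a 1.5-fold higher number from compound 3 to compound 4 (0.19 log units; within the scatter), though a step within the scatter cannot be ruled out. Compound 4 is therefore estimated at 40000 nM in this assay, with a range from 15000 nM to 100000 nM.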

Compound 4, half-maximal inhibitory concentration: 18400 nM
The estimate for compound 4 lay 2.2-fold (0.34 log units) above the measured number, within the range that was stated.
By their numbers in this assay, from the lowest: compounds 4 and 3 (each within the scatter of the next); then compound 2. At a limit, above all of these: compound 1.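

At this position, para to a large group, 4-chlorophenyl to 4-methoxyphenyl in this assay gives a 1.4-fold lower number from compound 3 to compound 4 (0.15 log units; within the scatter) and so does not separate the two groups, even though methoxy brings a hydrogen-bond acceptor and chloro does not. The replacement of nitro now reads a 3.4-fold lower number from compound 2 to compound 4 (0.53 log units; beyond the scatter), which, taken with a 2.4-fold lower number from compound 2 to compound 3 (0.38 log units; beyond the scatter), leaves nitro as the one substituent of the three that stands apart from the other two, with the higher number. The gain over the unsubstituted phenyl reads an at least 5.4-fold lower number from compound 1 to compound 4 (0.73 log units; beyond the scatter), which is only a floor, as compound 1 is a limit of the assay and not a number: the limit of > 100000 nM in this assay, at which 1 of the 4 values shown sits.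

Three substituents at one position cannot show whether the flat stretch shared by chloro and methoxy extends to fluoro, an amine, a hydroxyl, a carboxylic acid or a longer alkoxy chain. Nor do the compounds shown say whether the same order of groups would hold on the other phenyl ring or with the benzyl ether of the shared core replaced.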